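This account rests on a few compounds, and the source may have more. Where it says the series, first, only, none or still open, it means among the compounds named here.

Three nucleoside esters have been measured. Compound 1 `N[C@@H](CC(=O)OC[C@H]1O[C@@H](n2cc(F)c(=O)[nH]c2=O)C[C@@H]1O)C(=O)O` carries a 2-amino-2-carboxyethyl group on a carbonyl carbon, and in an ADME assay on tissue (ZR-75-1 cells, Homo sapiens) for pharmacokinetics (a higher number here means that the compound lasts longer, a lower number that the compound disappears faster), compound 1 gives 0.223 h. Compound 2 `CC(C)[C@H](N)C(=O)OC[C@H]1O[C@@H](n2cc(F)c(=O)[nH]c2=O)C[C@@H]1O` differs from compound 1 by 1-amino-2-methylpropyl in place of 2-amino-2-carboxyethyl on a carbonyl carbon, and in this assay compound 2 gives 0.273 h; this change gave a 1.2-fold higher number from compound 1 to compound 2 (0.09 log units; within the scatter). Compound 3 `N[C@@H](CC(=O)O[C@H]1C[C@H](n2cc(F)c(=O)[nH]c2=O)O[C@@H]1CO)C(=O)O` has the same atoms as compound 1 joined differently; the difference between the two cores is not broken down here. In this assay compound 3 gives 0.403 h. Compound 4 `CC(C)[C@H](N)C(=O)O[C@H]1C[C@H](n2cc(F)c(=O)[nH]c2=O)O[C@@H]1CO` has not yet been measured; it differs from compound 3 by 1-amino-2-methylpropyl in place of 2-amino-2-carboxyethyl on a carbonyl carbon, the same change as that between compound 1 and compound 2, at a place described in identical words. Because the earlier change gave a 1.2-fold higher number from compound 1 to compound 2 (0.09 log units; within the scatter), compound 4 is expected to show a 1.2-fold higher number from compound 3 to compound 4 (0.08 log units; within the scatter). The estimate for compound 4 in this assay is 0.49 h, with a range from 0.25 h to 0.95 h.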

Compound 4, half-life: 0.153 h
For compound 4 the middle estimate is 3.2-fold (0.51 log units) above the measured one; measured number outside the range, below it.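

In this assay, 1-amino-2-methylpropyl in place of 2-amino-2-carboxyethyl on a carbonyl carbon gave a 2.6-fold lower number from compound 3 to compound 4 (0.42 log units; beyond the scatter). The change did not carry over from the core of compound 1 to the core of compound 3: the same change on two cores in this assay, a 1.2-fold higher number (0.09 log units; within the scatter) from compound 1 to compound 2 and a 2.6-fold lower number (0.42 log units; beyond the scatter) from compound 3 to compound 4, 3.2-fold (0.51 log units) apart, beyond the scatter of two such steps. A step read on one of these cores therefore cannot be taken over to the other, but a single pair on each core does not show why they part, nor how any other group would behave.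

The compounds shown leave open whether a plain alkyl chain without the amine, or a longer chain, would also behave differently on the two cores. They also leave open whether an amide in place of the ester would do so.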